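Removing One Methyl From a Compound at the Limit

The source may hold more compounds than are shown below. What is called first, only, known or untested is meant among the compounds shown, and "the series" means these compounds.

In a functional assay on 786-0 cells (Homo sapiens) (on this read-out higher numbers stand for weaker inhibition of growth and lower numbers for stronger inhibition of growth), compound 1 (`Cc1cc(C)c2c(O)cc(-c3ccc(Cl)cc3)nc2n1`) gives 21400 nM as its reading. Compound 2 (`COc1ccccc1-c1cc(O)c2ccc(C)nc2n1`) reads > 100000 nM and this is a limit of the assay, not a number. Compound 3 (`COc1ccccc1-c1cc(O)c2cccnc2n1`) differs from compound 2 by hydrogen in place of methyl on an aromatic carbon, next to the ring nitrogen (hydrogen in place of methyl on an aromatic carbon). Within the data shown here, no measured pair of compounds shows this change, so only an expectation is possible. In this assay the expected step is none beyond the scatter (a number no higher from compound 2 to compound 3 (the limit leaves the size open)). For compound 3 the estimated value is 100000 nM with an expected range from 40000 nM to 250000 nM on this read-out.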

Compound 3, concentration for 50% growth inhibition: 36300 nM
For compound 3 the middle estimate is 2.8-fold (0.44 log units) above the measured one; the measured number lies below the stated range.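

In this assay, hydrogen in place of methyl on this aromatic carbon, next to the ring nitrogen, gives an at least 2.7-fold lower number from compound 2 to compound 3 (0.44 log units; beyond the scatter), so growth inhibition at this position does respond to the change. Compound 2 reads > 100000 nM, which is a limit of the assay and not a number. The full size of the step stays unknown because compound 2 sits at that limit: the limit of > 100000 nM in this assay, at which 1 of the 3 values shown sits.

On these data alone, how an ethyl chain or an amine at this position would read remains open. Compound 1 differs from compound 3 in more than one place, so it cannot settle this.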